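The source may report more compounds than this note shows. Statements on the series, on what has been measured and on what is new or still open speak of the compounds shown alone.

Among the measured compounds shown here, three related compounds have numbers so far in a functional assay on HeLa cells (Homo sapiens) for antiproliferative activity, read by sulforhodamine B assay, with a stated time of 48 h; a higher number here means a weaker inhibitor, a lower number a stronger inhibitor. Compound 1 `COc1cc(C(=O)/C=C\Nc2ccc(-c3nc4cc(OC)c(OC)c(OC)c4s3)cc2C)cc([N+](=O)[O-])c1OC` gives 13100 nM, compound 2 `COc1cc(OC)c2sc(-c3ccc(N/C=C\C(=O)c4cc(OC)c(OC)c([N+](=O)[O-])c4)c(C)c3)nc2c1` gives 11400 nM, and compound 3 `COc1cc(OC)c2sc(-c3ccc(N/C=C\C(=O)c4ccc(OC)c(F)c4)c(C)c3)nc2c1` gives 14700 nM. These values lie within the usual scatter of one another, so compound 1 stands level with the other two and they cannot be ranked.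

Compound 4 `COc1cc(C(=O)/C=C\Nc2ccc(-c3nc4cc(OC)c(OC)c(OC)c4s3)cc2)cc([N+](=O)[O-])c1OC` has not yet been measured. It differs from compound 1 in a single place: hydrogen in place of methyl on an aromatic carbon. In words, this is hydrogen in place of methyl on an aromatic carbon of a six-membered aromatic ring of carbon only.

For the measured compounds named here, no measured step makes this exact change, since all three tested compounds carry the methyl. The nearest evidence is a 1.1-fold lower number from compound 1 to compound 2 (0.06 log units; within the scatter). That step also puts hydrogen on an aromatic carbon, but in place of methoxy and at another place in the molecule, so it is only a loose guide. Its small size gives no reason to expect a large change here, though it cannot rule one out. No step beyond the scatter is therefore expected in this assay, and the expected step is a 1.1-fold lower number from compound 1 to compound 4 (0.04 log units; within the scatter). The range is kept wide because the methyl has never been removed in a measured pair. For compound 4 the estimated value is 12000 nM, with an expected range from 5000 nM to 28000 nM.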

Compound 4, half-maximal inhibitory concentration: 7800 nM
Beside the measured number, compound 4's estimate is 1.5-fold (0.19 log units) above it, and the stated range covers the measured number.
By their numbers in this assay, from the lowest: compounds 4, 2, 1 and 3 (each within the scatter of the next).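

In this assay the methyl on an aromatic carbon of the six-membered aromatic ring of carbon only, ortho to a large group and meta to a large group, gives way to hydrogen in this one pair, and the outcome is a 1.7-fold lower number from compound 1 to compound 4 (0.23 log units; within the scatter) and so no real difference between the two compounds can be claimed. For this pair, then, the methyl is not needed for the level of activity seen with compound 1, although a single pair with numbers this close cannot show that the position has no influence at all. Nothing among the available data offers an explanation for this result.

The compounds shown carry only methyl or hydrogen at this position, so it remains open whether a different group there, such as an ethyl, a chlorine atom or an amine, would shift the number beyond the scatter. Going by these compounds, it also remains open whether the same swap of methyl for hydrogen would give a similarly small step in compound 2 or compound 3, which differ from compound 1 elsewhere in the molecule.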